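Moving the chlorine on the aryl ring of compound 3

A few compounds are considered here, and "the series" means these few. Any claim that something is new, unique, unknown or untested is made for them only; others in the source may bear on it.

Compound 3 `Cc1ccc(S(=O)(=O)NC(=O)Nc2ccccc2C(=O)/C=C/c2ccccc2Cl)cc1` was tested in an ADME assay on the whole organism for cytotoxicity, with Artemia salina as the target, with a stated time of 24 h (on this read-out higher numbers stand for an effect only at larger amounts of compound and lower numbers for an effect already at smaller amounts), and gave 12.8 ug/mL. Two other compounds from the same series share its core and differ only in the aryl group on the double-bonded chain carbon. Compound 1 `COc1cccc(/C=C/C(=O)c2ccccc2NC(=O)NS(=O)(=O)c2ccc(C)cc2)c1` gave 23.2 ug/mL in this assay, and compound 2 `COc1cc(/C=C/C(=O)c2ccccc2NC(=O)NS(=O)(=O)c2ccc(C)cc2)ccc1O` gave 17.8 ug/mL in this assay. The exchange of aryl groups is recorded as a 1.8-fold lower number from compound 1 to compound 3 (0.26 log units; within the scatter) and as a 1.4-fold lower number from compound 2 to compound 3 (0.14 log units; within the scatter), so compound 3 sits among numbers that are not separated from its own beyond the scatter; the change between the two other compounds, a 1.3-fold lower number from compound 1 to compound 2 (0.12 log units; within the scatter), is also within it.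

The next compound, compound 4 `Cc1ccc(S(=O)(=O)NC(=O)Nc2ccccc2C(=O)/C=C/c2ccc(Cl)cc2)cc1`, differs from compound 3 by 4-chlorophenyl in place of 2-chlorophenyl on a double-bonded chain carbon bound to a double-bonded chain carbon. Among the measured compounds shown here, no measured step moves the chlorine around the ring; the two steps that change the aryl group on that chain carbon, a 1.8-fold lower number from compound 1 to compound 3 (0.26 log units; within the scatter) and a 1.4-fold lower number from compound 2 to compound 3 (0.14 log units; within the scatter), were both within the scatter. The expectation for compound 4 in this assay is therefore no step beyond the scatter, as a 1.0-fold higher number from compound 3 to compound 4 (0.01 log units; within the scatter). Compound 4 is estimated at 13 ug/mL in this assay, with a range from 6.5 ug/mL to 26 ug/mL.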

Compound 4, concentration for half-maximal effect: 6.92 ug/mL
For compound 4 the middle estimate is 1.9-fold (0.27 log units) above the measured one; the range from low to high includes it.
By their numbers in this assay, from the lowest: compounds 4, 3, 2 and 1 (each within the scatter of the next, the first and the last beyond it).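

In this assay, 4-chlorophenyl in place of 2-chlorophenyl on a double-bonded chain carbon bound to a double-bonded chain carbon gives a step that stays within the scatter (a 1.8-fold lower number from compound 3 to compound 4 (0.27 log units; within the scatter)), so this first measured move of the chlorine around the ring does not separate the two compounds. Among the compounds shown here, what the earlier compounds did not show is an aryl exchange at this place that passes beyond the scatter: 4-chlorophenyl in place of 4-hydroxy-3-methoxyphenyl gives a modest step (a 2.6-fold lower number from compound 2 to compound 4 (0.41 log units; beyond the scatter)), and 4-chlorophenyl in place of 3-methoxyphenyl gives another (a 3.4-fold lower number from compound 1 to compound 4 (0.53 log units; beyond the scatter)), whereas the corresponding exchanges to 2-chlorophenyl remained within it. Nothing in the available data gives a reason for these steps.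

The compounds shown leave open what 3-chlorophenyl would give at this place, and whether unsubstituted phenyl would stand with the two chlorophenyl compounds or with the two methoxy-bearing ones. They also leave open whether 4-fluorophenyl, 4-bromophenyl or 4-aminophenyl would keep the number near that of 4-chlorophenyl.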